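Aryl swap on the sulfonyl sulfur: working notes

A few compounds are considered here, and "the series" means these few. Any claim that something is new, unique, unknown or untested is made for them only; others in the source may bear on it.

Measured in a functional assay on VCaP cells (Homo sapiens) for antiproliferative activity, read by propidium iodide staining, with a stated time of 96 h (a higher number here means a weaker inhibitor, a lower number a stronger inhibitor), so far:
- compound 1 `CC(O)(CSc1ccccc1C(F)(F)F)C(=O)Nc1cccc(S(F)(F)(F)(F)F)c1` gives 21000 nM
- compound 2 `CC(O)(CS(=O)(=O)c1ccc(F)cc1)C(=O)Nc1ccc(S(F)(F)(F)(F)F)cc1` gives 34200 nM

Among the measured compounds shown here, compound 2 and compound 1 lie within the scatter of each other, so compound 2 stands level with the only other measured compound. Compound 3 `CC(O)(CS(=O)(=O)c1cccc(OC(F)(F)F)c1)C(=O)Nc1ccc(S(F)(F)(F)(F)F)cc1` is not yet measured. It carries 3-(trifluoromethoxy)phenyl in place of 4-fluorophenyl on a sulfonyl sulfur. For the measured compounds named here, the series holds no measured step between two compounds differing in one place, so nothing shows how this change acts in this assay and no shift beyond the scatter is expected. The estimated step is a 1.6-fold lower number from compound 2 to compound 3 (0.19 log units; within the scatter) with a direction that remains tentative. For compound 3 the estimated value is 22000 nM with an expected range from 8000 nM to 50000 nM in this reading.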

Compound 3, half-maximal inhibitory concentration: 23700 nM
Estimate against measurement, compound 3: 1.1-fold (0.03 log units) below; low and high end bracket the measured number.
By their numbers in this assay, from the lowest: compounds 1, 3 and 2 (each within the scatter of the next).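

In this assay the series now has its first one-place step: a 1.4-fold lower number from compound 2 to compound 3 (0.16 log units; within the scatter) and so no real shift when 3-(trifluoromethoxy)phenyl stands in place of 4-fluorophenyl on a sulfonyl sulfur. At this position, the two aryl groups therefore read as level, although the entering group adds a hydrogen-bond acceptor. No measured evidence bears on this result.

Still open, on these data alone, is whether any aryl group is needed on the sulfonyl sulfur, or whether a short alkyl chain would read the same. An amine or a carboxylic acid on the aryl ring also remains untested within the compounds shown.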